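A few compounds are considered here, and "the series" means these few. Any claim that something is new, unique, unknown or untested is made for them only; others in the source may bear on it.

In a functional assay on MCF7 cells (Homo sapiens) for cytotoxicity, in the presence of a further agent that is not named here (on this read-out higher numbers stand for an effect only at larger amounts of compound and lower numbers for an effect already at smaller amounts), compound 1 (`CCCCCCCO[C@@H]1[C@@H](O)[C@@H](OCc2ccccc2)O[C@@H]2CO[C@@H](c3ccc(OC)cc3)O[C@@H]12`) gives 2.5 ug/mL and compound 2 (`CCCCCCCO[C@@H]1[C@@H](OCc2ccccc2)[C@@H](OCc2ccccc2)O[C@H](CO)[C@H]1OCc1ccc(OC)cc1`) gives 3 ug/mL so that compound 2 stands within the scatter of compound 1. Compound 3 (`CCCCCCCO[C@@H]1[C@@H](OCc2ccccc2)[C@@H](OCc2ccccc2)O[C@H](CC(C)C)[C@H]1OCc1ccc(OC)cc1`) differs from compound 2 in one place, with isopropyl in place of hydroxy on a saturated chain carbon bound to a saturated ring carbon is the counted change. Among the measured compounds shown here, no measured step between these compounds shows the effect of such a change. The expected step of a 1.3-fold higher number from compound 2 to compound 3 (0.12 log units; within the scatter) in this assay is therefore modest and points to a higher number. Compound 3 is estimated at 4 ug/mL with 1.5 ug/mL to 12 ug/mL as its expected range.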

Compound 3, half-maximal effective concentration: > 20 ug/mL
Compound 3 gave a limit, no number; the forecaster's own chance of this, stated with the estimate: 10%; middle value at least 5.0-fold (0.69 log units) from the limit.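

This position had shown no step before. With isopropyl in place of hydroxy on a saturated chain carbon bound to a saturated ring carbon, this assay shows an at least 6.6-fold higher number from compound 2 to compound 3 (0.82 log units; beyond the scatter). Compound 3 gives > 20 ug/mL, which is a limit of the assay and not a number, so the step gives only a lower bound on the size of this change: the limit of > 20 ug/mL in this assay, at which 1 of the 3 values shown sits.

The compounds shown leave open whether the loss of hydroxy or the entry of isopropyl accounts for the step. They also leave open how an amine or a carboxylic acid would read at this place.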